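The compounds below may be only part of what the source reports. "The series", "measured", "known", "first", "only" and "open" are said of these compounds alone.

Measured in a functional assay on HepG2 cells (Homo sapiens) for cytotoxicity, read by MTT assay, with a stated time of 24 h; on this read-out lower numbers stand for stronger inhibition and higher numbers for weaker inhibition:
compound 1 `CN1C/C(=C\c2ccc(C(C)(C)C)cc2)C(=O)/C(=C/c2ccccc2F)C1` gives 9120 nM
compound 2 `CN1C/C(=C\c2ccc(C#N)cc2)C(=O)/C(=C/c2ccccc2F)C1` gives 590 nM
compound 3 `COc1cc(/C=C2\CN(C)C/C(=C\c3cc(OC)c(OC)c(OC)c3)C2=O)cc(OC)c1` gives 890 nM

Compound 3 at 890 nM sits within the scatter of compound 2 at 590 nM and clearly under compound 1 at 9120 nM on this scale. Compound 4 `COc1cc(/C=C2\CN(C)C/C(=C\c3cccc([N+](=O)[O-])c3)C2=O)cc(OC)c1OC` awaits measurement: it carries 3-nitrophenyl in place of 3,5-dimethoxyphenyl on a double-bonded chain carbon bound to a double-bonded ring carbon. For the measured compounds named here, the one measured step, a 15-fold lower number from compound 1 to compound 2 (1.19 log units; beyond the scatter) for cyano in place of tert-butyl on an aromatic carbon, involves other groups, so it bears only loosely: such a swap can be large, but this step does not settle the direction here. In this assay a small downward move is therefore expected, with the estimated step (a 1.5-fold lower number from compound 3 to compound 4 (0.17 log units; within the scatter)) inside the scatter. Compound 4 is estimated at 600 nM (expected range 200 nM to 1800 nM).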

Compound 4, half-maximal inhibitory concentration: 1890 nM
Compound 4: middle estimate off by 3.2-fold (0.50 log units), on the low side; measured number outside the range, above it.
By their numbers in this assay, from the lowest: compounds 2 and 3 (each within the scatter of the next); then compound 4; then compound 1.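

Putting 3-nitrophenyl in place of 3,5-dimethoxyphenyl on a double-bonded chain carbon bound to a double-bonded ring carbon gives a 2.1-fold higher number from compound 3 to compound 4 (0.33 log units; beyond the scatter) in this assay and so moves the number modestly, toward weaker inhibition. For the compounds shown here, the earlier step concerned a different swap, so this is the first sign that the group at this place can change the result. A single step cannot show whether an amine or a carboxylic acid on that ring would do better or worse. Nothing available explains why the number rose here.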